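The compounds below may be only part of what the source reports. "The series", "measured", "known", "first", "only" and "open" are said of these compounds alone.

Measured so far in an ADME assay on Vero cells (Chlorocebus sabaeus) for cytotoxicity, read by MTT assay, with a stated time of 72 h (a higher number here means a weaker inhibitor, a lower number a stronger inhibitor), for this series:
Compound 1 `COc1ccc(NC(=S)NNC(=O)c2cc([N+](=O)[O-])c[nH]2)cc1` at 331000 nM
Compound 2 `O=C(NNC(=S)Nc1ccc(F)cc1)c1cc([N+](=O)[O-])c[nH]1` at 331000 nM
Compound 3 `Cn1cc([N+](=O)[O-])cc1C(=O)NNC(=S)Nc1ccc(F)cc1` at 662000 nM

Compound 2 stands level with compound 1 at the digits shown, and it has no step beyond the scatter to either of the other two compounds. Compound 4 `O=C(NNC(=S)Nc1ccccc1F)c1cc([N+](=O)[O-])c[nH]1` has not yet been measured. It has the same atoms as compound 2, joined differently: 2-fluorophenyl in place of 4-fluorophenyl on an amide-type nitrogen with 2-fluorophenyl in place of 4-fluorophenyl on an amide-type nitrogen.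

Within the data shown here, two measured steps bear on this change, though neither tests it directly. Fluoro in place of methoxy on an aromatic carbon gave no change at the digits printed from compound 1 to compound 2 (within the scatter) and methyl in place of hydrogen on an aromatic nitrogen gave a 2.0-fold higher number from compound 2 to compound 3 (0.30 log units; within the scatter) in this assay here. With both of these steps that small, no shift beyond the scatter is expected, in either direction. The expected result is no change at the digits printed from compound 2 to compound 4 (within the scatter) in this measurement. Compound 4 is estimated at 331000 nM with an expected range from 165000 nM to 662000 nM in this measurement.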

Compound 4, half-maximal inhibitory concentration: 471000 nM
Beside the measured number, compound 4's estimate is 1.4-fold (0.15 log units) below it; low and high end bracket the measured number.
By their numbers in this assay, from the lowest: compounds 1, 2, 4 and 3 (each within the scatter of the next).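

In this assay, 2-fluorophenyl in place of 4-fluorophenyl on the amide-type nitrogen gave a 1.4-fold higher number from compound 2 to compound 4 (0.15 log units; within the scatter), with the atoms of the compound unchanged. The earlier steps had exchanged one group for another or added a methyl on an aromatic nitrogen, whereas this one changes only how the fluoro-bearing ring is joined, and it too gives no shift beyond the scatter, so all the steps shown at this position and on the shared core remain small in this measurement. No measurement shown here offers an explanation for this reading.

The compounds shown leave open whether a different group on this phenyl ring, such as a trifluoromethyl, a carboxylic acid or an amine, would produce a step beyond the scatter, given that only methoxy and fluoro have been compared there. From the compounds shown here alone, it is also open whether the 2-fluorophenyl group would read the same with a methyl on the aromatic nitrogen, as in compound 3, or with a carbonyl in place of the thiocarbonyl carbon's sulfur.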